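A few compounds are considered here, and "the series" means these few. Any claim that something is new, unique, unknown or untested is made for them only; others in the source may bear on it.

Measured compounds:
Compound 1 `COc1ccc(-c2oc3c(OC)c(OC)cc(OCCCC(=O)NCc4ccccn4)c3c(=O)c2O)cc1` — in a functional assay on A549 cells (Homo sapiens) for antiproliferative activity, read by sulforhodamine B assay, with a stated time of 48 h (on this read-out higher numbers stand for weaker inhibition and lower numbers for stronger inhibition), compound 1 gives > 40000 nM, which is a limit of the assay and not a number.
Compound 2 `COc1ccc(-c2oc3c(OC)c(OC)cc(OCCCC(=O)N4CCN(C)CC4)c3c(=O)c2O)cc1` — in this assay compound 2 gives > 40000 nM, again a limit of the assay.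
Compound 3 `COc1ccc(-c2oc3c(OC)c(OC)cc(OCCCCCC(=O)N4CCN(C)CC4)c3c(=O)c2O)cc1` — in this assay compound 3 gives 14800 nM.

Compound 3 is the only one of the three with a number; the other two sit at the limit of > 40000 nM in this assay, at which 2 of the 3 values shown sit. The step that the two limits leave unreadable from compound 2 to compound 1 is therefore unreadable. The longer chain gives an at least 2.7-fold lower number from compound 2 to compound 3 (0.43 log units; beyond the scatter) and an at least 2.7-fold lower number from compound 1 to compound 3 (0.43 log units; beyond the scatter).

Compound 4 `COc1ccc(-c2oc3c(OC)c(OC)cc(OCCCCCC(=O)NCc4ccccn4)c3c(=O)c2O)cc1` carries the change (((pyridin-2-yl)methyl)amino in place of 4-methylpiperazin-1-yl on a carbonyl carbon). The same kind of change, (((pyridin-2-yl)methyl)amino in place of 4-methylpiperazin-1-yl on a carbonyl carbon), links compound 2 to compound 1, where both values are limits, so its size is not known. The cores of compound 3 and compound 2 differ by 2-((4-methylpiperazin-1-yl)carbonyl)ethyl in place of (4-methylpiperazin-1-yl)carbonyl on a saturated chain carbon, three bonds along the chain from an oxygen on an aromatic ring; the two places are described in the same words.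

With nothing readable from the earlier pair, the step from compound 3 to compound 4 is expected to be small, about a 1.0-fold higher number from compound 3 to compound 4 (0.01 log units; within the scatter). Compound 4 is thus estimated at 15000 nM, between 5000 nM and 45000 nM.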

Compound 4, half-maximal inhibitory concentration: > 40000 nM
Compound 4: no number, only a limit; the forecaster's own chance of this, stated with the estimate: 30%; middle value at least 2.6-fold (0.42 log units) from the limit.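

In this assay compound 4 gives > 40000 nM, which is a limit of the assay and not a number. Going by these compounds, on the core of compound 3, ((pyridin-2-yl)methyl)amino in place of 4-methylpiperazin-1-yl on a carbonyl carbon gives an at least 2.7-fold higher number from compound 3 to compound 4 (0.43 log units; beyond the scatter), and the full size of this step remains unknown. The same change on the core of compound 2, which gives compound 1, cannot be read, and neither can the other steps that join two limits, so the compounds do not show whether the change has the same size on both cores, and any reading of the series rests on a single number: the limit of > 40000 nM in this assay, at which 3 of the 4 values shown sit.

The compounds shown leave open whether a chain longer than that of compound 3 would give a lower number in this assay, with either 4-methylpiperazin-1-yl or ((pyridin-2-yl)methyl)amino on the carbonyl carbon. They also leave open how another amine, such as morpholine, or a carboxylic acid at that carbonyl carbon would read.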